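This account rests on a few compounds, and the source may have more. Where it says the series, first, only, none or still open, it means among the compounds named here.

Compound 3 `Cc1cn(-c2cc(CN3CCN(C)CC3)cc(NC(=O)c3ccc(C)c(Nc4nccc(-c5ccccc5)n4)c3)c2)cn1` carries a (4-methylpiperazin-1-yl)methyl group on the shared core. Going by the values given here, in an ADME assay on the whole organism (Mus musculus, strain CD1) for pharmacokinetics, read by LC-MS, using cassette dosing, with a stated time of 24 h, at a dose of 0.4 mg/kg by the intravenous route (a higher number here means that more of the compound sits outside the plasma, a lower number that more of the compound stays in the plasma), compound 3 gives 5.65 L/kg, the largest of the three numbers so far, although a 1.3-fold higher number from compound 2 to compound 3 (0.12 log units; within the scatter) and a 1.5-fold higher number from compound 1 to compound 3 (0.18 log units; within the scatter) keep it within the scatter of compound 2 `Cc1cn(-c2cc(NC(=O)c3ccc(C)c(Nc4nccc(-c5ccccc5)n4)c3)cc(N3CCN(C)CC3)c2)cn1` with 4.3 L/kg and compound 1 `Cc1cn(-c2cc(NC(=O)c3ccc(C)c(Nc4nccc(-c5ccccc5)n4)c3)cc(N3CCNCC3)c2)cn1` with 3.74 L/kg. Compound 4 `Cc1cn(-c2cc(CCS(N)(=O)=O)cc(NC(=O)c3ccc(C)c(Nc4nccc(-c5ccccc5)n4)c3)c2)cn1` differs from compound 3 by sulfamoylmethyl in place of 4-methylpiperazin-1-yl on a saturated chain carbon bound to an aromatic carbon. Among the compounds with values here, no measured step covers a change of this kind: the steps seen, including a 1.1-fold higher number from compound 1 to compound 2 (0.06 log units; within the scatter), only vary the same ring-bearing group and all stay within the scatter. The expectation therefore rests on the counted difference alone and carries a wide range. Compound 4 is estimated at 1.6 L/kg, between 0.6 L/kg and 4 L/kg, an expected step of a 3.5-fold lower number from compound 3 to compound 4 (0.55 log units; beyond the scatter).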

Compound 4, volume of distribution at steady state: 1.72 L/kg
Beside the measured number, compound 4's estimate is 1.1-fold (0.03 log units) below it; the measured number falls inside the stated range.
By their numbers in this assay, from the lowest: compound 4; then compounds 1, 2 and 3 (each within the scatter of the next).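

Replacing the ring-bearing groups with 2-sulfamoylethyl, a chain with no ring, produces steps beyond the scatter in this assay: a 3.3-fold lower number from compound 3 to compound 4 (0.52 log units; beyond the scatter), a 2.5-fold lower number from compound 2 to compound 4 (0.40 log units; beyond the scatter) and a 2.2-fold lower number from compound 1 to compound 4 (0.34 log units; beyond the scatter). The number at this position therefore can move beyond the scatter, which the changes among compounds 1, 2 and 3 did not show. Nothing shown here accounts for the drop. Ring and end group change together, so it remains open which of them goes with the lower number. A plain alkyl chain, or a chain ending in an amine or a carboxylic acid, remains untested among the compounds shown.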